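Methyl in place of hydrogen: expected tolerance of compound 4

The compounds below may be only part of what the source reports. "The series", "measured", "known", "first", "only" and "open" are said of these compounds alone.

Compound 1 `Cc1ccc(/C=N/N(C(=O)c2ccccc2)C(=O)c2ccncc2)cc1` gives >= 20 ug/mL in an ADME assay on Vero cells (Chlorocebus sabaeus) for cytotoxicity (a lower number here means that less compound is tolerated, a higher number that more compound is tolerated), a limit of the assay.
Compound 2 `COc1cc(/C=N/N(C(=O)c2ccccc2)C(=O)c2ccncc2)ccc1O` gives >= 100 ug/mL in this assay, a limit.
Compound 3 `CSc1ccc(/C=N/N(C(=O)c2ccccc2)C(=O)c2ccncc2)cc1` gives >= 100 ug/mL in this assay, a limit.

Compound 2 stands at the limit of >= 100 ug/mL in this assay, at which 2 of the 3 values shown sit, so for it only a limit is known, not a number. The three steps between measured compounds, a step that the two limits leave unreadable from compound 1 to compound 2, a step that the two limits leave unreadable from compound 1 to compound 3 and a step that the two limits leave unreadable from compound 2 to compound 3, cannot be read in size, as each end is a limit. Compound 4 `CCOc1cc(/C=N/N(C(=O)c2ccccc2)C(=O)c2ccncc2)ccc1O` differs from compound 2 by methyl in place of hydrogen on a saturated chain carbon bound to an oxygen on an aromatic ring. Going by the values given here, no measured step touches that part of the structure, so none bears on it directly. Because compound 2 sits at the limit of >= 100 ug/mL in this assay, at which 2 of the 3 values shown sit, compound 4 is expected to show a step of a number no higher from compound 2 to compound 4 (the limit leaves the size open) in this assay, most likely ending as a limit again. The estimate for compound 4 is 100 ug/mL, between 50 ug/mL and 200 ug/mL.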

Compound 4, minimum cytotoxic concentration: > 100 ug/mL
Compound 4: no number, only a limit (the forecaster's own chance of this, stated with the estimate: 75%); the middle value sits exactly at the limit.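

Compound 2 and compound 4 are each known only as a limit in this assay, so the step between them cannot be read. The compounds shown leave open whether ethoxy in place of methoxy alters tolerance at all.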